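Anilinoquinazoline series: swapping the 4-fluorophenyl for 2-methylphenyl

The source may report more compounds than this note shows. Statements on the series, on what has been measured and on what is new or still open speak of the compounds shown alone.

Compound 1, `Fc1ccc(Nc2nc(-c3cccc(F)c3)nc3ccc(F)cc23)cc1`, is tested in a functional assay on COLO 205 cells (Homo sapiens) for cytotoxicity, read by MTT assay, with a stated time of 48 h; on this read-out higher numbers stand for weaker inhibition and lower numbers for stronger inhibition. In this assay compound 1 reaches only a limit and no number, > 50000 nM. Its position on the numbers shown is therefore (the limit of > 50000 nM in this assay, at which 1 of the 2 values shown sits). Compound 2, `Fc1cccc(-c2nc(Nc3ccc(Cl)cc3)c3cc(F)ccc3n2)c1`, gives 32600 nM in this assay, and the change chloro in place of fluoro on an aromatic carbon produces an at least 1.5-fold lower number from compound 1 to compound 2 (0.18 log units; that floor lies within the scatter). Compound 3, `Cc1ccccc1Nc1nc(-c2cccc(F)c2)nc2ccc(F)cc12`, has not yet been measured; relative to compound 1 the difference is 2-methylphenyl in place of 4-fluorophenyl on a nitrogen on an aromatic ring. Within the data shown here, no measured step concerns the group on the ring nitrogen, so the single step from compound 1 to compound 2 carries no direct information on this change, and the only anchor is the limit of compound 1. Compound 3 is therefore expected to remain weak in this assay, with an estimate of 45000 nM and a range from 15000 nM to 150000 nM. The step this estimate implies, an at least 1.1-fold lower number from compound 1 to compound 3 (0.04 log units; that floor lies within the scatter), is expected to stay within the scatter.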

Compound 3, half-maximal inhibitory concentration: > 50000 nM
Compound 3 ended at the assay's limit; the forecaster's own chance of this, stated with the estimate: 50%; at least 1.1-fold (0.04 log units) between middle value and limit.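

With 2-methylphenyl on the nitrogen, compound 3 stays at the end of the range in this assay, so this change, like the 4-fluorophenyl group of compound 1, gives no number: the limit of > 50000 nM in this assay, at which 2 of the 3 values shown sit. The step between compound 1 and compound 3 cannot be read, since both values are limits. Replacing 4-chlorophenyl with 2-methylphenyl gives an at least 1.5-fold higher number from compound 2 to compound 3 (0.18 log units; that floor lies within the scatter), so the group on the nitrogen is not shown to matter beyond the scatter, although the true size of this step may be larger than its floor.

The compounds shown leave open whether any group on this nitrogen gives a clear gain in this assay. A 4-methoxyphenyl or a benzyl group there might tell, and so might a carboxylic acid on the ring.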